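Removing the aryl cap: compound 1 to compound 4

The source may report more compounds than this note shows. Statements on the series, on what has been measured and on what is new or still open speak of the compounds shown alone.

In a functional assay on MCF7 cells (Homo sapiens) for antiproliferative activity, read by MTT assay, with a stated time of 48 h (on this read-out lower numbers stand for stronger inhibition of growth and higher numbers for weaker inhibition of growth), compound 1 `CCOc1cc(NC(=O)CCCCCC(=O)Nc2cc(-c3ccc(C)s3)ccc2N)cc2c1OCC([N+](=O)[O-])=C2` reaches only the limit of the assay, > 20000 nM, so no number stands for it (the limit of > 20000 nM in this assay, at which 1 of the 3 values shown sits). Two companions with a phenyl group in place of the 5-methylthiophen-2-yl and with chains of other lengths do give numbers: compound 2 `CCOc1cc(NC(=O)CCCCC(=O)Nc2cc(-c3ccccc3)ccc2N)cc2c1OCC([N+](=O)[O-])=C2` gives 19900 nM in this assay, and compound 3 `CCOc1cc(NC(=O)CCCCCCC(=O)Nc2cc(-c3ccccc3)ccc2N)cc2c1OCC([N+](=O)[O-])=C2` gives 9370 nM, so both sit in the weak range, with compound 3 the lower of the two.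

Compound 4 `CCOc1cc(NC(=O)CCCCCC(=O)Nc2ccccc2N)cc2c1OCC([N+](=O)[O-])=C2` differs from compound 1 by a single change, (hydrogen in place of 5-methylthiophen-2-yl on an aromatic carbon). Within the data shown here, with only a limit for compound 1 and no measured step of this kind among the three compounds, the size of the step cannot be read from the data; compound 1 is already at the limit, and compound 4 is expected to stay at or beyond that same region, with the change a step that the limit leaves unreadable from compound 1 to compound 4 expected to be small or to lie within the scatter. Compound 4 is therefore estimated at 30000 nM in this assay, within a range from 10000 nM to 100000 nM, with a real chance that the assay again reports only a limit.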

Compound 4, concentration for 50% growth inhibition: 19500 nM
Compound 4: middle estimate off by 1.5-fold (0.19 log units), on the high side; the range from low to high includes it.
By their numbers in this assay, from the lowest: compound 3; then compounds 4 and 2 (each within the scatter of the next). At a limit, above all of these: compound 1.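

In this assay, hydrogen in place of 5-methylthiophen-2-yl on this aromatic carbon gives an at least 1.0-fold lower number from compound 1 to compound 4 (0.01 log units; that floor lies within the scatter), so the change yields a floor and not a size. Compound 4 gives a real number, 19500 nM, which shows that a measurable value in this assay does not depend on the 5-methylthiophen-2-yl, although that value remains in the weak range. The step stays a floor because compound 1 has only a limit: the limit of > 20000 nM in this assay, at which 1 of the 4 values shown sits.

The compounds shown leave open how large the step from the 5-methylthiophen-2-yl to hydrogen really is, and whether the thiophene ring makes any difference to growth inhibition at all. They also leave open how a phenyl group, a small group such as fluorine or methoxy, or an amine on this same carbon would read with the chain of compound 4, and whether a longer chain would carry this uncapped compound out of the weak range.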